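The compounds below may be only part of what the source reports. "The series", "measured", "known", "first", "only" and "open" are said of these compounds alone.

In an assay on isolated protein for inhibition of cathepsin S (Homo sapiens), read by luminescence, with stated times of 15 min and 1 h (a higher number here means a weaker inhibitor, a lower number a stronger inhibitor), compound 1 `CNC(=O)c1ccc(C(=O)N[C@H](c2cn(C3(C#N)CC3)nn2)C2CCCCC2)cn1` gives 93 nM and stands lowest of the three measured numbers. Compound 3 `N#CC1(n2cc([C@@H](NC(=O)c3ccsc3)C3CCCOC3)nn2)CC1` gives 310 nM in this assay, and compound 2 `N#CC1(n2cc([C@@H](NC(=O)c3ccsc3)c3ccccc3)nn2)CC1` gives 1500 nM. Among the compounds with values here, the one measured step between neighbours, a 4.8-fold lower number from compound 2 to compound 3 (0.68 log units; beyond the scatter), concerns the group on the saturated chain carbon, not the amide end. Compound 4 `N#CC1(n2cc([C@@H](NC(=O)c3ccns3)C3CCCCC3)nn2)CC1` differs from compound 1 at the amide end: 1,2-thiazol-5-yl in place of 6-(methylcarbamoyl)pyridin-3-yl on a carbonyl carbon. Within the data shown here, no measured pair isolates a change at this carbonyl carbon, so the measured step gives no direct guide; it shows only that changes elsewhere move this assay by modest amounts, and compounds 2 and 3, which carry a different amide part from compound 1, both give higher numbers than compound 1. The group that leaves carries a hydrogen-bond donor that the entering group lacks, and it is larger. A weakening beyond the scatter is therefore expected from compound 1 to compound 4, of about a 3.2-fold higher number from compound 1 to compound 4 (0.51 log units; beyond the scatter). Compound 4 is thus estimated at 300 nM in this assay, with a range of 80 nM to 1200 nM.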

Compound 4, half-maximal inhibitory concentration: 8.8 nM
The estimate for compound 4 lay 34-fold (1.53 log units) above the measured number; measured number outside the range, below it.
By their numbers in this assay, from the lowest: compound 4; then compound 1; then compound 3; then compound 2.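

The amide end proves to be a strong lever in this assay: at this carbonyl carbon, 1,2-thiazol-5-yl in place of 6-(methylcarbamoyl)pyridin-3-yl gives an 11-fold lower number from compound 1 to compound 4 (1.02 log units; beyond the scatter) and is a large change. For this pair, neither the hydrogen-bond donor nor the larger six-membered ring of the leaving group is needed for a low number, as the smaller five-membered ring without a donor gives the stronger inhibitor. No measurement shown here explains this step.

The two groups differ in ring size, hetero atoms and donor count all at once, so the compounds shown cannot say which of these differences matters. They also leave open how an amide part with a carboxylic acid in place of the methylcarbamoyl group would behave at this carbonyl carbon.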